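A few compounds are considered here, and "the series" means these few. Any claim that something is new, unique, unknown or untested is made for them only; others in the source may bear on it.

Of the compounds shown here, three have so far been measured in an assay on cell membranes from Cerebral cortex for displacement of a labelled ligand from Sigma non-opioid intracellular receptor 1 (Cavia porcellus), read by scintillation counting, with a stated time of 120 min; a higher number here means a weaker inhibitor, a lower number a stronger inhibitor. Compound 3 `CN(CCCCn1nc(-c2ccccc2)oc1=O)Cc1ccccc1` gives 5.2 nM. Compound 2 `CN(CCCCN1C(=O)CSc2ccccc21)Cc1ccccc1` gives 5 nM, a number within the scatter of compound 3, so no order between the two can be read from these values. The difference between the core of compound 2 and the core of compound 3 is not broken down here. Compound 1 `CN(CCCCn1nc(-c2ccccc2)oc1=O)Cc1ccc(Cl)cc1` gives 18.7 nM. Compound 1 differs from compound 3 in a single place, (chloro in place of hydrogen on an aromatic carbon), and this single change made the step of a 3.6-fold higher number from compound 3 to compound 1 (0.56 log units; beyond the scatter).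

Compound 4 `CN(CCCCN1C(=O)CSc2ccccc21)Cc1ccc(Cl)cc1` has not yet been measured. Going by the values given here, it differs from compound 2 by chloro in place of hydrogen on an aromatic carbon, a change of the same kind as the one from compound 3 to compound 1, and the description of the place is the same in both cases. This change therefore occurs twice among the compounds shown, once measured and once still open. Compound 4 is expected to give 18 nM, with a likely range from 8 nM to 45 nM. The expected step is a 3.6-fold higher number from compound 2 to compound 4 (0.56 log units; beyond the scatter), because the same kind of change gave a 3.6-fold higher number from compound 3 to compound 1 (0.56 log units; beyond the scatter) on the other core. Whether the second core responds in the same way remains to be seen.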

Compound 4, inhibition constant: 13 nM
The estimate for compound 4 lay 1.4-fold (0.14 log units) above the measured number; low and high end bracket the measured number.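

In this assay, replacing phenyl with 4-chlorophenyl on the core of compound 2 gave a 2.6-fold higher number from compound 2 to compound 4 (0.41 log units; beyond the scatter), so chloro made the compound a weaker inhibitor on this core too. Two pairs of compounds are a small base, however: they do not show that the change would act the same way on a third core, and they do not explain why the number rises. What they do show is that, on these two cores, the change went in the same direction and by a similar amount: the same change on two cores in this assay, a 3.6-fold higher number (0.56 log units; beyond the scatter) from compound 3 to compound 1 and a 2.6-fold higher number (0.41 log units; beyond the scatter) from compound 2 to compound 4, 1.4-fold (0.14 log units) apart, within the scatter of two such steps

The compounds shown leave open whether another group in the same place, such as fluoro or methoxy, would also give a higher number. They also leave open whether the effect of chloro would persist with a longer chain in place of the present one linking the core to the amine.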